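This account rests on a few compounds, and the source may have more. Where it says the series, first, only, none or still open, it means among the compounds named here.

Among the measured compounds shown here, in a functional assay on HT-29 cells (Homo sapiens) for inhibition, read by luminescence and CellTiter-Glo, with a stated time of 24 h (on this read-out lower numbers stand for an effect already at smaller amounts and higher numbers for an effect only at larger amounts of compound), compound 1 `CCn1nc(C(=O)N[C@H]2COc3ccccc3N(C)C2=S)nc1Cc1ccccc1` gives 17 nM, while compound 2 `CN1C(=S)[C@@H](NC(=O)c2nc(Cc3ccccc3)n(C3CCOCC3)n2)COc2ccccc21` gives 2260 nM, the higher of the two numbers measured so far. For the measured compounds named here, only one measured step bears on what follows: a 130-fold higher number from compound 1 to compound 2 (2.12 log units; beyond the scatter), a large change that comes with swapping the group on an aromatic nitrogen. Compound 3 `CN1C(=S)[C@@H](NC(=O)c2nc(Cc3ccccc3)n(Cc3ccccc3)n2)COc2ccccc21` changes that group again, (benzyl in place of oxan-4-yl on an aromatic nitrogen), with benzyl in place of oxan-4-yl. Going by the values given here, no measured compound carries benzyl there, so the direction is uncertain, but the expectation in this assay, resting on a 130-fold higher number from compound 1 to compound 2 (2.12 log units; beyond the scatter), is a partial return towards compound 1 rather than a full one. The expected change is a 7.5-fold lower number from compound 2 to compound 3 (0.88 log units; beyond the scatter), a moderate one towards a lower number. For compound 3 the estimate is 300 nM, with an expected range from 40 nM to 2500 nM.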

Compound 3, half-maximal effective concentration: 414 nM
Compound 3: the middle estimate sits 1.4-fold (0.14 log units) below what was measured; low and high end bracket the measured number.
By their numbers in this assay, from the lowest: compound 1; then compound 3; then compound 2.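

In this assay, the change on the aromatic nitrogen gives a 5.5-fold lower number from compound 2 to compound 3 (0.74 log units; beyond the scatter), so a large ring-bearing group at this position need not carry the full penalty seen with oxan-4-yl. Even so, a 24-fold higher number from compound 1 to compound 3 (1.39 log units; beyond the scatter) and leaves ethyl with the lowest number of the three; benzyl has 7 heavy atoms against 6 for oxan-4-yl, so among these two groups the number does not rise with heavy-atom count. Nothing available explains why benzyl and oxan-4-yl differ here.

As far as these compounds go, whether methyl or a propyl chain on this nitrogen would match compound 1 or go lower remains open. From the compounds shown here alone, it is also open whether a benzyl group carrying a hydroxyl or an amine on its ring would move the number further in either direction.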